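Fluoro for trifluoromethyl on the anilide ring

A few compounds are considered here, and "the series" means these few. Any claim that something is new, unique, unknown or untested is made for them only; others in the source may bear on it.

Measured compounds:
compound 1 `COc1ccc(C(F)(F)F)cc1NC(=O)CN1CCN(S(=O)(=O)N2CCC(C)CC2)CC1`: 2400 nM
compound 2 `COc1ccc(Cl)cc1NC(=O)N1CC2(C1)CN(S(=O)(=O)N1CCC(C)CC1)C2`: > 10000 nM

The series is followed in an assay on HEK293 cells for inhibition of potassium channel subfamily T member 1 (Homo sapiens), read by thallium flux; on this read-out higher numbers stand for weaker inhibition and lower numbers for stronger inhibition. Within the data shown here, compound 1 is the only compound with a numerical value here, so it is the sole reference point for the next step. Compound 2 does not give a number in this assay; the assay reports only a limit for it, > 10000 nM, and this is the point of the limit of > 10000 nM in this assay, at which 1 of the 2 values shown sits. Among the measured compounds shown here, compound 2 also differs from compound 1 in more than one place, so no step between the two can be read from their values.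

Compound 3 `COc1ccc(F)cc1NC(=O)CN1CCN(S(=O)(=O)N2CCC(C)CC2)CC1` keeps the shared core of compound 1 and changes one group: fluoro in place of trifluoromethyl on an aromatic carbon. For the measured compounds named here, no measured step of this kind stands in the set, so the direction and size of the change are an expectation only. A modest weakening is expected, of a size that may lie just beyond the scatter, so that the step from compound 1 to compound 3 is estimated as a 1.9-fold higher number from compound 1 to compound 3 (0.27 log units; within the scatter). Compound 3 is therefore expected to give about 4500 nM in this assay, with a range from 1500 nM to 14000 nM.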

Compound 3, half-maximal inhibitory concentration: 4900 nM
Compound 3: middle estimate off by 1.1-fold (0.04 log units), on the low side; low and high end bracket the measured number.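

Among these compounds, on this assay, the change gives a 2.0-fold higher number from compound 1 to compound 3 (0.31 log units; beyond the scatter), the first step that can be read at a single place, and it shows that this position, para to a methoxy group, responds to fluoro in place of trifluoromethyl, though only modestly. Fluoro still gives a numerical value, so trifluoromethyl is not needed at this position for inhibition to register on this read-out. The step is also a comparison of two numbers and is not cut off by the upper end of the read-out, which is marked by a single entry in the set: the limit of > 10000 nM in this assay, at which 1 of the 3 values shown sits.

With one step at this position, the compounds shown do not tell whether the value follows the heavy-atom count of the group or something else, nor where a nitrile, a methyl or a bare hydrogen at the same carbon would fall relative to compound 1 and compound 3. Steps to compound 2 cannot be read: it differs in more than one place and gives only a limit.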